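Difluoromethyl for ethyl on the shared core

A few compounds are considered here, and "the series" means these few. Any claim that something is new, unique, unknown or untested is made for them only; others in the source may bear on it.

Compound 1 `Cc1cccnc1N1CCN(C(=O)Nc2ccc(C(C)C)cc2)CC1` gives 25.3 nM in a functional assay on HEK293 cells for antagonist activity at transient receptor potential cation channel subfamily V member 1 (Rattus norvegicus); a lower number here means a stronger inhibitor, a higher number a weaker inhibitor. Among the measured compounds shown here, compound 2 `CCc1cccnc1N1CCN(C(=O)Nc2ccc(C(C)C)cc2)CC1` gives 230 nM in this assay, and with the step of a 9.1-fold higher number from compound 1 to compound 2 (0.96 log units; beyond the scatter) as its only comparison, compound 2 stands with the highest number of the two. Compound 3 `CC(C)c1ccc(NC(=O)N2CCN(c3ncccc3C(F)F)CC2)cc1` carries the change difluoromethyl in place of ethyl on an aromatic carbon, ortho to a large group and two atoms from the ring nitrogen; cut one bond further out, 3-ethylpyridin-2-yl becomes 3-(difluoromethyl)pyridin-2-yl. For the measured compounds named here, only the step of a 9.1-fold higher number from compound 1 to compound 2 (0.96 log units; beyond the scatter) touches this position, and it shows that the group there can shift the number well beyond the scatter. The new group is not a return to the methyl of compound 1, so only a partial recovery is expected in this assay, the estimated step being a 2.9-fold lower number from compound 2 to compound 3 (0.46 log units; beyond the scatter). Compound 3 is therefore estimated at 80 nM, within 20 nM to 400 nM.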

Compound 3, half-maximal inhibitory concentration: 27.7 nM
Compound 3: the middle estimate sits 2.9-fold (0.46 log units) above what was measured; measured number inside the range.
By their numbers in this assay, from the lowest: compounds 1 and 3 (each within the scatter of the next); then compound 2.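

Difluoromethyl in place of ethyl gives an 8.3-fold lower number from compound 2 to compound 3 (0.92 log units; beyond the scatter) in this assay, so the number at this position does not simply rise with the heavy-atom count of the group: difluoromethyl counts more heavy atoms than ethyl, and compound 2 remains the one that goes against such a trend. Against methyl, the same group gives a 1.1-fold higher number from compound 1 to compound 3 (0.04 log units; within the scatter), which leaves compound 1 and compound 3 indistinguishable in this read-out. No measurement at hand accounts for the difference between ethyl and difluoromethyl.

Open, going by these compounds, is whether trifluoromethyl, monofluoromethyl or a chlorine atom at this position would stay with methyl and difluoromethyl or move towards ethyl. Also open, on these data alone, is whether the match between methyl and difluoromethyl holds once another part of the shared core changes.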